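The compounds below may be only part of what the source reports. "The series", "measured", "known", "first", "only" and "open" are said of these compounds alone.

Measured in a functional assay on T-24 cells (Homo sapiens) for antiproliferative activity, read by sulforhodamine B assay, with a stated time of 72 h; on this read-out lower numbers stand for stronger inhibition and higher numbers for weaker inhibition:
compound 1 `C=CCSc1ccc2c3c(cccc13)C1=NC(=O)C(C(=O)OCC(=O)SCCC)=C12`, 71800 nM
compound 2 `CCCSC(=O)COC(=O)C1=C2C(=NC1=O)c1cccc3c(SCCC)ccc2c13`, 79100 nM

Going by the values given here, compound 1 stands level with compound 2, its only measured neighbour: a 1.1-fold higher number from compound 1 to compound 2 (0.04 log units; within the scatter). That step places ethyl in place of vinyl on a saturated chain carbon bound to a sulfur, so it leaves untouched the group that changes next.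

Compound 3 `C=CCSc1ccc2c3c(cccc13)C1=NC(=O)C(C(=O)OCC)=C12` differs from compound 1 as follows: methyl in place of (propylsulfanyl)carbonyl on a saturated chain carbon bound to an oxygen next to a carbonyl group. In other words, (((propylsulfanyl)carbonyl)methoxy)carbonyl becomes ethoxycarbonyl. Among the compounds with values here, no measured step covers this change, and the data give it no direction. With nothing to indicate a shift, no step beyond the scatter is expected in this assay, though this rests on little evidence. The expected step is a 1.4-fold lower number from compound 1 to compound 3 (0.16 log units; within the scatter). For compound 3 the estimated value is 50000 nM, with an expected range from 12000 nM to 150000 nM.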

Compound 3, half-maximal inhibitory concentration: 700 nM
For compound 3 the middle estimate is 71-fold (1.85 log units) above the measured one; the whole stated range lies above it.
By their numbers in this assay, from the lowest: compound 3; then compounds 1 and 2 (each within the scatter of the next).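

In this assay this position carries far more weight than the end of the sulfur-bound chain: the change from (((propylsulfanyl)carbonyl)methoxy)carbonyl to ethoxycarbonyl gives a 100-fold lower number from compound 1 to compound 3 (2.01 log units; beyond the scatter), whereas the earlier change gave only a 1.1-fold higher number from compound 1 to compound 2 (0.04 log units; within the scatter). The entering methyl has 1 heavy atom against 6 heavy atoms in the leaving (propylsulfanyl)carbonyl, so the much lower number goes with the smaller group in this single pair. Nothing available explains the size of this step.

Going by these compounds, a single pair cannot separate loss of the sulfur from shortening of the chain, so it remains open how a carboxylic acid, an amide or a longer chain such as propoxycarbonyl would compare with ethoxycarbonyl here. Also open, on these data alone, is whether ethyl in place of vinyl stays as flat with ethoxycarbonyl on the core.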